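Cytotoxicity notes on a thiazolidinone series with piperidine side chain

This account rests on a few compounds, and the source may have more. Where it says the series, first, only, none or still open, it means among the compounds named here.

Measured so far in an ADME assay on Vero cells (Chlorocebus sabaeus) for cytotoxicity, read by neutral red uptake, tested at 394 ug/mL; on this read-out lower numbers stand for a stronger effect and higher numbers for a weaker effect at the one concentration tested:
compound 1 `O=C1CSC(c2ccc(O)cc2)N1CCN1CCCCC1`: 76%
compound 2 `COc1ccccc1C1SCC(=O)N1CCN1CCCCC1`: 67%
compound 3 `O=C1CSC(c2ccccc2[N+](=O)[O-])N1CCN1CCCCC1`: 100%

Compound 1 stands second highest of the three numbers in this assay. Its nearest neighbour is compound 2, whose value lies within the scatter of that of compound 1, so no order between the two can be read. The furthest is compound 3, which lies beyond the scatter and higher than compound 1.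

Among the measured compounds shown here, only one single-place step is available: a number 33 percentage points higher from compound 2 to compound 3 (beyond the scatter). It shows that one substituent swap on the aromatic ring of the shared core can move the read-out well beyond the scatter.

Compound 4 `O=C1CSC(c2ccc(Cl)cc2)N1CCN1CCCCC1` is not yet measured. It differs from compound 1 as follows: chloro in place of hydroxy on an aromatic carbon

For the measured compounds named here, no measured step shares this change, neither the leaving hydroxy nor the entering chloro appears elsewhere in the set, so the step from compound 2 to compound 3 bears on it only as a sign of how large a swap on the aromatic ring can be. The expected size of the step in this assay is therefore modest and uncertain; a small rise seems the more likely direction. The step expected from compound 1 to compound 4 is a number 6 percentage points higher from compound 1 to compound 4 (within the scatter). For compound 4 the estimate is 82%, within 62% to 100%.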

Compound 4, a percentage reported as activity, at one concentration (the size of the read-out at that concentration, not a potency): 28%
Beside the measured number, compound 4's estimate is 54 percentage points above it; the whole stated range lies above it.
By their numbers in this assay, from the lowest: compound 4; then compounds 2 and 1 (each within the scatter of the next); then compound 3.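

In this assay, the change from 4-hydroxyphenyl to 4-chlorophenyl, on an aromatic carbon para to a large group, gives a number 48 percentage points lower from compound 1 to compound 4 (beyond the scatter). Among the compounds shown here, the only earlier step on the aromatic ring ran upward, a number 33 percentage points higher from compound 2 to compound 3 (beyond the scatter), so this result adds a large step in the opposite direction and shows that replacing one heavy atom at this position is enough to move the read-out well beyond the scatter. Hydroxy carries a hydrogen-bond donor and a hydrogen-bond acceptor that chloro does not, but no measurement available here connects the drop to that difference or to any other property of the two groups.

On these data alone, it remains open whether the low number goes with the chloro itself or simply with the loss of the hydroxy; fluoro, methyl or amino at this same place would help separate those two readings. Also open, as far as these compounds go, is whether the chloro keeps this effect on the read-out when a morpholine replaces the piperidine of the side chain.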